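The source may hold more compounds than are shown below. What is called first, only, known or untested is meant among the compounds shown, and "the series" means these compounds.

In a functional assay (blood) for inhibition, with Homo sapiens as the target (on this read-out higher numbers stand for weaker inhibition and lower numbers for stronger inhibition), compound 1 (`CC(C)(C)Sc1c(CC(C)(C)C(=O)O)n(Cc2ccc(Cl)cc2)c2ccc(OCc3cc4ccccc4cn3)cc12`) reads > 3000 nM as a limit of the assay, not a number. Within the data shown here, compound 2 (`CC(C)(C)Sc1c(CC(C)(C)C(=O)O)n(Cc2ccc(Cl)cc2)c2ccc(OCc3nc4ccccc4s3)cc12`) gives 260 nM and so holds the only actual number so far. Among the measured compounds shown here, the one measured step (an at least 11-fold lower number from compound 1 to compound 2 (1.06 log units; beyond the scatter)) is large and lies beyond the scatter. It shows that the group on the oxygen-bound chain carbon can move the read-out strongly.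

Compound 3 (`COc1ccc2nc(COc3ccc4c(c3)c(SC(C)(C)C)c(CC(C)(C)C(=O)O)n4Cc3ccc(Cl)cc3)sc2c1`) carries a smaller change (methoxy in place of hydrogen on an aromatic carbon), methoxy in place of hydrogen on an aromatic carbon, so that 1,3-benzothiazol-2-yl becomes 6-methoxy-1,3-benzothiazol-2-yl. For the measured compounds named here, no measured step tests methoxy, and the earlier step replaced the whole group, so it bears only indirectly. It argues for a wide range in either direction rather than for a direction. With compound 2 at 260 nM as the anchor, the central expectation in this assay is no shift beyond the scatter. The expected step is a 1.1-fold lower number from compound 2 to compound 3 (0.05 log units; within the scatter) in this estimate. For compound 3 the estimate is 230 nM with 80 nM to 700 nM as the expected range.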

Compound 3, half-maximal inhibitory concentration: 670 nM
Estimate against measurement, compound 3: 2.9-fold (0.46 log units) below; the range from low to high includes it.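

In this assay, among these compounds, methoxy on the six-membered aromatic ring of carbon only gives a 2.6-fold higher number from compound 2 to compound 3 (0.41 log units; beyond the scatter); this is the first direct reading of a substituent on the 1,3-benzothiazol-2-yl group, and it shows that this carbon is not silent and that, in this single example, methoxy moves the read-out towards weaker inhibition. The advantage over isoquinolin-3-yl is nevertheless kept with the substituent in place, as 6-methoxy-1,3-benzothiazol-2-yl gives an at least 4.4-fold lower number from compound 1 to compound 3 (0.65 log units; beyond the scatter). Both comparisons with compound 1 give only a lower bound on the size of the step, because compound 1 stands at a limit of the assay and not at a number: the limit of > 3000 nM in this assay, at which 1 of the 3 values shown sits.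

A single substituent at a single carbon cannot show whether the shift belongs to methoxy in particular or would follow any group placed there, and a fluorine atom, a hydroxyl or an ethoxy group at the same carbon would separate these two readings. Also open, from the compounds shown here alone, is whether an amine or a carboxylic acid on this ring would shift the read-out in the same direction as methoxy or in the opposite one.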